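A few compounds are considered here, and "the series" means these few. Any claim that something is new, unique, unknown or untested is made for them only; others in the source may bear on it.

Measured so far:
compound 1 `COc1cc2c(Oc3ccc(NC(=O)NN4C(=O)CSC4c4c(F)cccc4F)cc3Cl)ccnc2cc1OCCCN1CCCC1` — 880 nM
compound 2 `COc1cc2c(Oc3c(F)cc(NC(=O)NN4C(=O)CSC4c4c(F)cccc4F)cc3F)ccnc2cc1OCCCN1CCc2sccc2C1` — > 20000 nM

In a functional assay on A549 cells (Homo sapiens) for antiproliferative activity, read by MTT assay, with a stated time of 72 h (a higher number here means a weaker inhibitor, a lower number a stronger inhibitor), compound 1 gives 880 nM. Compound 2 stands only at a limit of the assay, > 20000 nM, so no number is known for it; of the two results shown, (the limit of > 20000 nM in this assay, at which 1 of the 2 values shown sits). Compound 3 `CCN1CCN(CCCCOc2cc3nccc(Oc4c(F)cc(NC(=O)NN5C(=O)CSC5c5c(F)cccc5F)cc4F)c3cc2OC)CC1` differs from compound 2 by a group of 9 heavy atoms (7 carbon, 2 nitrogen; one six-membered non-aromatic ring with 2 hetero atoms) in place of a group of 9 heavy atoms (7 carbon, 1 nitrogen, 1 sulfur; one five-membered aromatic ring with 1 hetero atom, one six-membered non-aromatic ring with 1 hetero atom), on a saturated chain carbon, three bonds along the chain from an oxygen on an aromatic ring. For the measured compounds named here, no measured step covers this change, so its direction is open. Compound 3 is expected to sit near 12000 nM, in the range 2000 nM to 40000 nM, which would mean an expected step of an at least 1.6-fold lower number from compound 2 to compound 3 (0.22 log units; that floor lies within the scatter). A result that is again only a limit is expected to remain quite possible for compound 3.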

Compound 3, half-maximal inhibitory concentration: 1390 nM
For compound 3 the middle estimate is 8.6-fold (0.94 log units) above the measured one; measured number below the stated range.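

In this assay, the position on a saturated chain carbon, three bonds along the chain from an oxygen on an aromatic ring, proves sensitive to the group it carries: placing (4-ethylpiperazin-1-yl)methyl there in place of the group with the five-membered aromatic ring gives an at least 14-fold lower number from compound 2 to compound 3 (1.15 log units; beyond the scatter). Compound 2 stands at a limit of the assay and has no number, so this step is only a floor: the limit of > 20000 nM in this assay, at which 1 of the 3 values shown sits.

Whether the ethyl group or the piperazine ring itself accounts for the step remains open. As far as these compounds go, how a morpholine or a dimethylamine would read at this position also remains open.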